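A few compounds are considered here, and "the series" means these few. Any claim that something is new, unique, unknown or untested is made for them only; others in the source may bear on it.

Of the compounds shown here, two built on one shared core have been measured in a functional assay on HCT-116 cells (Homo sapiens) for cytotoxicity, read by sulforhodamine B assay, with a stated time of 72 h; a lower number here means a stronger inhibitor, a higher number a weaker inhibitor. Compound 1 `CCS(=O)(=O)Nc1cc(-c2ccc3ncnc(Nc4ccc(OC)c(OC)c4)c3c2)cnc1OC` gives 4360 nM in this assay, and compound 2 `CCS(=O)(=O)Nc1cc(-c2ccc3ncnc(Nc4ccc(Cl)c(C(=O)OC)c4)c3c2)cnc1OC` gives 3130 nM. For the measured compounds named here, the single step between them, a 1.4-fold lower number from compound 1 to compound 2 (0.14 log units; within the scatter), exchanges the whole aryl group on the nitrogen on the aromatic ring. Of the two numbers shown, compound 2 carries the smaller one, but its nearest neighbour is compound 1 and that gap lies within the scatter, so nothing separates them in this assay.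

Compound 3 `CCS(=O)(=O)Nc1cc(-c2ccc3ncnc(Nc4ccc(F)nc4)c3c2)cnc1OC` has not yet been measured in this assay. It differs from compound 2 by 6-fluoropyridin-3-yl in place of 4-chloro-3-(methoxycarbonyl)phenyl on a nitrogen on an aromatic ring. Going by the values given here, the only measured step that bears on this change is a 1.4-fold lower number from compound 1 to compound 2 (0.14 log units; within the scatter), which likewise replaced the aryl group on that nitrogen and stayed within the scatter. Among the compounds with values here, no other step is available. The expectation for compound 3 is therefore no step beyond the scatter, an estimated move of a 1.3-fold higher number from compound 2 to compound 3 (0.11 log units; within the scatter). Compound 3 is expected to give about 4000 nM in this assay, with an estimated range from 1500 nM to 12000 nM.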

Compound 3, half-maximal inhibitory concentration: 7620 nM
For compound 3 the middle estimate is 1.9-fold (0.28 log units) below the measured one; the range from low to high includes it.
By their numbers in this assay, from the lowest: compounds 2, 1 and 3 (each within the scatter of the next, the first and the last beyond it).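

In this assay, the aryl group on the nitrogen on an aromatic ring gives its first step beyond the scatter: 6-fluoropyridin-3-yl in place of 4-chloro-3-(methoxycarbonyl)phenyl gives a modest change (a 2.4-fold higher number from compound 2 to compound 3 (0.39 log units; beyond the scatter)). The same entering group in place of 3,4-dimethoxyphenyl stays within the scatter (a 1.7-fold higher number from compound 1 to compound 3 (0.24 log units; within the scatter)), so only compound 2 and compound 3 stand apart, while compound 1 cannot be separated from either. This position therefore responds to the choice of aryl group, but the change to compound 3 removes the chlorine and the methoxycarbonyl together and brings in a ring nitrogen and a fluorine, so the step cannot be assigned to any one of these parts.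

The compounds shown leave open how much of the step would remain with a 4-chlorophenyl, a 3-(methoxycarbonyl)phenyl or a 4-fluorophenyl group on that nitrogen, each of which would separate these parts. Nothing available here accounts for the step, so the reason for it remains unknown.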